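The source may hold more compounds than are shown below. What is called first, only, known or untested is meant among the compounds shown, and "the series" means these compounds.

Tested in a functional assay on MDA-MB-231 cells (Homo sapiens) for inhibition, read by sulforhodamine B assay, with a stated time of 48 h (on this read-out higher numbers stand for weaker inhibition and lower numbers for stronger inhibition), were three compounds sharing one core.

Three compounds measured in this assay:
compound 1, `CCOC(=O)CCO/N=C(/c1ccc(OC)c(OC)c1OC)c1cccc2ccccc12`: 15200 nM
compound 2, `CCOC(=O)CO/N=C(/c1ccc(OC)c(OC)c1OC)c1cccc2ccccc12`: 16400 nM
compound 3, `CCOC(=O)/C=C/CO/N=C(/c1ccc(OC)c(OC)c1OC)c1cccc2ccccc12`: > 20000 nM, which is a limit of this assay and not a number

For compound 3 only a limit is known, so its standing among the three is that it gives no number at all, as noted in the limit of > 20000 nM in this assay, at which 1 of the 3 values shown sits. The other two steps are small: a 1.1-fold higher number from compound 1 to compound 2 (0.03 log units; within the scatter) and an at least 1.2-fold higher number from compound 2 to compound 3 (0.08 log units; that floor lies within the scatter), with an at least 1.3-fold higher number from compound 1 to compound 3 (0.11 log units; that floor lies within the scatter); none of them reaches beyond the scatter.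

Compound 4, `COc1ccc(/C(=N/OCC(=O)O)c2cccc3ccccc23)c(OC)c1OC`, has not been measured. It differs from compound 3 in one place: carboxy in place of 2-(ethoxycarbonyl)ethenyl on a saturated chain carbon bound to an oxygen on an unsaturated carbon. No measured step here changes the group in this place to a carboxy group, so the shown steps cannot tell the direction. Since compound 3 gives > 20000 nM, compound 4 is expected to sit near that limit too, with a step that the limit leaves unreadable from compound 3 to compound 4 estimated. Compound 4 is expected at about 25000 nM, within 8000 nM to 80000 nM.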

Compound 4, half-maximal inhibitory concentration: > 20000 nM
Compound 4 was reported as a limit (the forecaster's own chance of this, stated with the estimate: 65%); the middle value lies beyond the limit too.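

In this assay, among the compounds shown here, compound 4, the one compound here with a carboxy group in this place, gives > 20000 nM, which is a limit of the assay and not a number. Setting hydrogen in place of ethyl on the ester of compound 2 gives an at least 1.2-fold higher number from compound 2 to compound 4 (0.08 log units; that floor lies within the scatter), and the change from the longer ester chain gives an at least 1.3-fold higher number from compound 1 to compound 4 (0.11 log units; that floor lies within the scatter), so the carboxy group is not shown to improve on either ester, though these floors cannot say how much weaker it may be. The step from compound 3 to compound 4 cannot be read, and the saturated short-chain carboxy compound now stands at the same limit as the unsaturated ester: the limit of > 20000 nM in this assay, at which 2 of the 4 values shown sit.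

From the compounds shown here alone, how far compound 3 and compound 4 lie past that limit stays open. So does whether an amide, an amine or a primary alcohol on this chain would give a readable number in this assay.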